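The compounds below may be only part of what the source reports. "The series", "measured", "known", "first", "only" and "open" are said of these compounds alone.

Working notes on the series in a functional assay on SMMC-7721 cells (Homo sapiens) for antiproliferative activity, read by MTT assay, with a stated time of 48 h; a lower number here means a stronger inhibitor, a higher number a weaker inhibitor.

Of the compounds shown here, three have numbers so far. Compound 1 `COc1cc(OC)c2c(=O)c(OCCCOc3ccc(/C=C/C(=O)/C=C/c4scnc4C)cc3)c(-c3cc(OC)c(OC)c(OC)c3)oc2c1` gives 34300 nM in this assay. Compound 2 `COc1cc(OC)c2c(=O)c(OCCCOc3ccccc3/C=C/C(=O)/C=C/c3ccccn3)c(-c3cc(OC)c(OC)c(OC)c3)oc2c1` gives 3180 nM. Compound 3 `COc1cc(OC)c2c(=O)c(OCCCCOc3ccccc3/C=C/C(=O)/C=C/c3ccco3)c(-c3cc(OC)c(OC)c(OC)c3)oc2c1` gives 8480 nM, which places it second highest of the three; its nearest neighbour is compound 2 with a lower number beyond the scatter, and compound 1 stands furthest away with a higher number, also beyond the scatter.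

Compound 4 `COc1cc(OC)c2c(=O)c(OCCCCOc3ccccc3/C=C/C(=O)/C=C/c3ccc(Cl)cc3)c(-c3cc(OC)c(OC)c(OC)c3)oc2c1` has not yet been run in this assay. It differs from compound 3 in one place: 4-chlorophenyl in place of furan-2-yl on a double-bonded chain carbon bound to a double-bonded chain carbon. Among the compounds with values here, no pair among the measured compounds differs in exactly this way, so the size of the step has no direct precedent here; the measured compounds differ from one another in several places at once, and all of their differences from each other lie beyond the scatter.

With nothing in the data that isolates this change, the step from compound 3 to compound 4 is expected to be small, a 1.3-fold lower number from compound 3 to compound 4 (0.12 log units; within the scatter), most likely within or just beyond the scatter and with no firm direction. Compound 4 is therefore estimated at 6500 nM in this assay, with a range from 2500 nM to 17000 nM.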

Compound 4, half-maximal inhibitory concentration: 41700 nM
For compound 4 the middle estimate is 6.4-fold (0.81 log units) below the measured one, outside the stated range (above it).
By their numbers in this assay, from the lowest: compound 2; then compound 3; then compounds 1 and 4 (each within the scatter of the next).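

In this assay the replacement of furan-2-yl by 4-chlorophenyl on a double-bonded chain carbon bound to a double-bonded chain carbon gives a 4.9-fold higher number from compound 3 to compound 4 (0.69 log units; beyond the scatter) and thus a weaker inhibitor. Within the data shown here, this is the first step that isolates a single change, and it shows that the group at this place alone can shift the number beyond the scatter, which the earlier compounds, differing in several places at once, could not show. The step gives a direction for this one exchange only, and nothing measured for these compounds accounts for it.

Open, from the compounds shown here alone, is whether the loss follows the chlorine or the six-membered carbon ring that carries it, a question that an unsubstituted phenyl or a 4-aminophenyl at the same place on the otherwise unchanged structure of compound 3 would help to separate. Also open, going by these compounds, is whether the same exchange gives a step of similar size and direction on a shorter or longer chain, or with the aryl ether arrangement seen in compound 1.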